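The source may report more compounds than this note shows. Statements on the series, on what has been measured and on what is new or still open speak of the compounds shown alone.

In a functional assay on PC-3M cells (Homo sapiens) for cytotoxicity, read by MTT assay, with a stated time of 48 h (on this read-out higher numbers stand for weaker inhibition and lower numbers for stronger inhibition), compound 1 `COc1ccc(C(=O)CSc2nnc(-c3cc(OC)c(OC)c(OC)c3)n2N2C(=O)c3ccccc3C2=O)cc1` gives 32800 nM. Among the compounds with values here, compound 2 `COc1cc(-c2nnc(SCC(=O)c3ccc(Br)cc3)n2N2C(=O)c3ccccc3C2=O)cc(OC)c1OC` gives 22600 nM; on the two numbers so far the step of a 1.5-fold lower number from compound 1 to compound 2 (0.16 log units; within the scatter) is the only comparison, and it lies within the scatter, so no order between the two compounds can be read. Compound 3 `COc1cc(-c2nnc(SCC(=O)c3ccc(F)c(F)c3)n2N2C(=O)c3ccccc3C2=O)cc(OC)c1OC` differs from compound 2 by 3,4-difluorophenyl in place of 4-bromophenyl on a carbonyl carbon. Within the data shown here, the one measured step that bears on this exchange of one substituted phenyl for another, a 1.5-fold lower number from compound 1 to compound 2 (0.16 log units; within the scatter), stayed within the scatter, so the expected step is a 1.1-fold higher number from compound 2 to compound 3 (0.04 log units; within the scatter), nothing beyond the scatter. For compound 3 the estimate in this assay is 25000 nM, expected between 10000 nM and 60000 nM.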

Compound 3, half-maximal inhibitory concentration: 163000 nM
Beside the measured number, compound 3's estimate is 6.5-fold (0.81 log units) below it; the measured number lies above the stated range.
By their numbers in this assay, from the lowest: compounds 2 and 1 (each within the scatter of the next); then compound 3.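

In this assay, the group on the carbonyl carbon now clearly matters: 3,4-difluorophenyl in place of 4-bromophenyl gives a 7.2-fold higher number from compound 2 to compound 3 (0.86 log units; beyond the scatter), and in place of 4-methoxyphenyl it gives a 5.0-fold higher number from compound 1 to compound 3 (0.70 log units; beyond the scatter), both towards weaker inhibition. The earlier pair, which lay within the scatter, therefore did not mean that any substituted phenyl behaves alike here. Nothing available explains this loss. Still open, from the compounds shown here alone, is whether 4-fluorophenyl, or a phenyl carrying an amine or a carboxylic acid, would match compound 2 or compound 3.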